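Lengthening the acyl chain: from propyl to butyl

A few compounds are considered here, and "the series" means these few. Any claim that something is new, unique, unknown or untested is made for them only; others in the source may bear on it.

In a functional assay on HeLa cells (Homo sapiens) for inhibition, with a stated time of 48 h, tested at 50 uM (on this read-out higher numbers stand for more inhibition of growth at the one concentration tested and lower numbers for less inhibition of growth), compound 1 `C=C[C@@](C)(/C=C/c1ccc(OC(C)=O)cc1)CCC=C(C)C` gives 63% while compound 2 `C=C[C@@](C)(/C=C/c1ccc(OC(=O)CC)cc1)CCC=C(C)C` gives 48% and compound 3 `C=C[C@@](C)(/C=C/c1ccc(OC(=O)CCC)cc1)CCC=C(C)C` gives 36% as the lowest of the three numbers. Compound 4 `C=C[C@@](C)(/C=C/c1ccc(OC(=O)CCCC)cc1)CCC=C(C)C` differs from compound 3 by methyl in place of hydrogen on a saturated chain carbon, three bonds along the chain from a carbonyl carbon and the change reads propyl to butyl. Two measured steps of the same kind bear on this change. The number falls with a number 15 percentage points lower from compound 1 to compound 2 (beyond the scatter) and again with a number 12 percentage points lower from compound 2 to compound 3 (beyond the scatter) and each of these modest steps lies beyond the scatter. A further modest fall is therefore expected in this assay and the estimated step is a number 11 percentage points lower from compound 3 to compound 4 (beyond the scatter) for this one change. For compound 4 the estimated value is 25% with 12% to 37% as the expected range.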

Compound 4, percent growth inhibition at one concentration: 23%
For compound 4 the middle estimate is 2 percentage points above the measured one, and the stated range covers the measured number.
By their numbers in this assay, from the lowest: compound 4; then compound 3; then compound 2; then compound 1.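

Among these compounds, the fall continues at this position in this assay, with a number 13 percentage points lower from compound 3 to compound 4 (beyond the scatter), and the full run reaches a number 40 percentage points lower from compound 1 to compound 4 (beyond the scatter), the only large step. Methyl in place of hydrogen gives a similar step at two places along the chain: the same change on two cores in this assay, a number 15 percentage points lower (beyond the scatter) from compound 1 to compound 2 and a number 13 percentage points lower (beyond the scatter) from compound 3 to compound 4, 2 percentage points apart, within the scatter of two such steps Ethyl in place of hydrogen, here a number 25 percentage points lower from compound 2 to compound 4 (beyond the scatter), also repeats its earlier step: the same change on two cores in this assay, a number 27 percentage points lower (beyond the scatter) from compound 1 to compound 3 and a number 25 percentage points lower (beyond the scatter) from compound 2 to compound 4, 2 percentage points apart, within the scatter of two such steps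

Going by these compounds, whether the fall persists with a chain longer than butyl remains open. So does the effect of a branched chain, or of an amine or carboxylic acid at the chain end.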